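Two Aminothiophenes and a Rearranged Fluorine Pattern

A few compounds are considered here, and "the series" means these few. Any claim that something is new, unique, unknown or untested is made for them only; others in the source may bear on it.

Among the measured compounds shown here, compound 1 `Nc1scc(CN2CCN(c3c(F)cccc3F)CC2)c1C(=O)c1cccc(C(F)(F)F)c1` and compound 2 `Nc1scc(CN2CCN(c3ccc(F)cc3F)CC2)c1C(=O)c1ccc(Cl)cc1` share one core and differ from each other in two places at once, so no single step joins them. In an assay on CHO cells for displacement of a labelled ligand from adenosine receptor A3 (Homo sapiens), read by scintillation counting, with a stated time of 120 min, tested at 10 uM (a lower number here means less inhibition, a higher number more inhibition at the concentration tested (going by the name of the read-out)), compound 1 gives 0%, and in this assay compound 2 gives 0%, level with compound 1 at the digits shown and inside the usual scatter. Compound 3 `Nc1scc(CN2CCN(c3c(F)cccc3F)CC2)c1C(=O)c1ccc(Cl)cc1` has not yet been tested. Its structure departs from compound 2 by 2,6-difluorophenyl in place of 2,4-difluorophenyl on an amine nitrogen in a ring, which places on compound 3 the same 2,6-difluorophenyl that compound 1 carries. Since compound 1 shows 0% and compound 2 shows 0%, the account expects no step beyond the scatter in this assay, in either direction. The expected step from compound 2 to compound 3 is a number 2 percentage points higher from compound 2 to compound 3 (within the scatter). Compound 3 is therefore estimated at 2%, with a range from 0% to 12%.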

Compound 3, a percentage reported as inhibition, at one concentration (the size of the read-out at that concentration, not a potency): 4%
The estimate for compound 3 lay 2 percentage points below the measured number, within the range that was stated.
By their numbers in this assay, from the lowest: compounds 1, 2 and 3 (each within the scatter of the next).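

In this assay the 2,6-difluorophenyl in place of 2,4-difluorophenyl on the amine nitrogen in a ring, now read as a single change, gives a number 4 percentage points higher from compound 2 to compound 3 (within the scatter) and does not leave the scatter. The other single change, 4-chlorophenyl in place of 3-(trifluoromethyl)phenyl on the carbonyl carbon, gives a number 4 percentage points higher from compound 1 to compound 3 (within the scatter) and likewise stays inside it. The two changes that separate compound 1 from compound 2 can thus be read one at a time, though nothing measured here accounts for this result.

The compounds shown leave open whether any other group on the amine nitrogen in a ring, such as a phenyl carrying a methoxy group, would give a number beyond the scatter. They also leave open what a carboxylic acid or an amine on the aromatic ring at the carbonyl carbon would do in place of the chlorine or the trifluoromethyl.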